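Bromo in Place of Methyl on the Ester Ring

This account rests on a few compounds, and the source may have more. Where it says the series, first, only, none or still open, it means among the compounds named here.

Of the compounds shown here, two built on one shared core have been measured in a functional assay on HepG2 cells (Homo sapiens), read by MTT assay, with a stated time of 72 h; a higher number here means a weaker inhibitor, a lower number a stronger inhibitor. Compound 1 `O=C(Oc1ccc(Cl)cc1C(=O)Nc1ccc(Cl)c(Cl)c1)c1ccc(Br)cc1` gives 2500 nM in this assay. Compound 2 `Cc1ccc(C(=O)Oc2ccc(Cl)cc2C(=O)Nc2ccc(C(F)(F)F)cc2)cc1` gives 6900 nM in this assay, the higher of the two numbers, and its distance from compound 1 lies beyond the usual scatter. For the measured compounds named here, compound 1 and compound 2 differ in two places at once, so no single step between them can be read from these numbers. Compound 3 `O=C(Oc1ccc(Cl)cc1C(=O)Nc1ccc(C(F)(F)F)cc1)c1ccc(Br)cc1` has not yet been measured. It differs from compound 2 in one place: bromo in place of methyl on an aromatic carbon. With no single-change comparison among the measured compounds, the direction of this step in this assay cannot be read from the measured pair, and a change within the usual scatter is the plainest expectation. Compound 3 is expected to give 4500 nM in this assay, with a likely range from 1500 nM to 13000 nM. This estimate means a 1.5-fold lower number from compound 2 to compound 3 (0.19 log units; within the scatter), a step expected to stay within the usual scatter.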

Compound 3, half-maximal inhibitory concentration: 14500 nM
Beside the measured number, compound 3's estimate is 3.2-fold (0.51 log units) below it; the whole stated range lies below it.
By their numbers in this assay, from the lowest: compound 1; then compound 2; then compound 3.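

Bromo in place of methyl gives the first single-change reading at this position: in this assay, going from 4-methylphenyl to 4-bromophenyl brings a 2.1-fold higher number from compound 2 to compound 3 (0.32 log units; beyond the scatter), a modest loss of strength beyond the usual scatter. With the 4-bromophenyl ester held fixed, 4-(trifluoromethyl)phenyl in place of 3,4-dichlorophenyl on the amide-type nitrogen brings a 5.8-fold higher number from compound 1 to compound 3 (0.76 log units; beyond the scatter), also modest and beyond the scatter, so both single changes shown here raise the number. Nothing available here accounts for either step.

The compounds shown compare only methyl and bromo at this position, leaving open what a methoxy group, an amine or a carboxylic acid would do there. Also open, on these data alone, is whether bromo in place of methyl gives a similar step with 3,4-dichlorophenyl on the amide-type nitrogen.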